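This account rests on a few compounds, and the source may have more. Where it says the series, first, only, none or still open, it means among the compounds named here.

Measured so far:
- compound 1 `Cc1cc2c(cc1C)C(Cl)=C(c1nnc(S)n1-c1ccccc1)CCC2`: 2640 nM
- compound 2 `Cc1ccc(-c2nnc(C3=C(Cl)c4cc(C)c(C)cc4CCC3)o2)cc1`: 1760 nM

These two compounds were tested in a functional assay on MDA-MB-231 cells (Homo sapiens) for antiproliferative activity, read by sulforhodamine B assay, with a stated time of 48 h; a lower number here means a stronger inhibitor of growth, a higher number a weaker inhibitor of growth. Compound 2 gives 1760 nM and compound 1 gives 2640 nM. These numbers lie within the usual scatter of each other, so the data cannot rank the two compounds.

The next compound to be tested is compound 3 `Cc1cc2c(cc1C)C(Cl)=C(c1nnc(-c3cccc(Cl)c3)o1)CCC2`. It keeps the rest of compound 2 but has 3-chlorophenyl in place of 4-methylphenyl on an aromatic carbon.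

The two measured compounds do not differ in just one place, so they offer no measured guide to this swap. With nothing to suggest a larger shift, no change beyond the scatter is expected. The expected change is a 1.2-fold lower number from compound 2 to compound 3 (0.07 log units; within the scatter). Compound 3 is expected to give 1500 nM, with an estimated range of 500 nM to 4500 nM.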

Compound 3, concentration for 50% growth inhibition: 3310 nM
Compound 3: middle estimate off by 2.2-fold (0.34 log units), on the low side; low and high end bracket the measured number.
By their numbers in this assay, from the lowest: compounds 2, 1 and 3 (each within the scatter of the next).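

In this assay, among these compounds, the swap of 3-chlorophenyl in place of 4-methylphenyl on the aromatic carbon of the five-membered ring gives a 1.9-fold higher number from compound 2 to compound 3 (0.27 log units; within the scatter) and is the first comparison here that differs in one place only. For this one pair, then, the aryl group at this position can be exchanged with no change beyond the scatter, so the data do not show that this swap matters for growth inhibition. Nothing at hand offers an explanation for this result.

The swap alters both the substituent and where it sits on the phenyl ring, and 4-chlorophenyl or 3-methylphenyl would be needed to separate the two. As far as these compounds go, it also remains open whether an unsubstituted phenyl, a pyridine ring, or a phenyl carrying an amine or a carboxylic acid would give a step beyond the scatter.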